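Swapping acetyl for methoxy at the assay limit

The source may hold more compounds than are shown below. What is called first, only, known or untested is meant among the compounds shown, and "the series" means these compounds.

Measured in a functional assay on KYSE-410 cells (Homo sapiens) for antiproliferative activity, read by MTT assay, with a stated time of 72 h (a lower number here means a stronger inhibitor, a higher number a weaker inhibitor), each entry being a limit and not a number:
Compound 1 `O=C(Nc1cccc(F)c1)c1cc(=O)[nH]c2cc(F)ccc12`: > 20000 nM
Compound 2 `O=C(Nc1cccc(F)c1)c1cc(=O)[nH]c2cc(-c3ccccc3)ccc12`: > 20000 nM
Compound 3 `CC(=O)c1ccc(-c2ccc3c(C(=O)Nc4cccc(F)c4)cc(=O)[nH]c3c2)cc1`: > 20000 nM

Compound 3 has no exact place on the scale, since its > 20000 nM is a limit of the assay. The whole set stands at the limit of > 20000 nM in this assay, at which 3 of the 3 values shown sit.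

Compound 4 `COc1ccc(-c2ccc3c(C(=O)Nc4cccc(F)c4)cc(=O)[nH]c3c2)cc1` has methoxy in place of acetyl on an aromatic carbon, para to a large group: methoxy in place of acetyl on an aromatic carbon. The same difference, seen one bond further out, is 4-acetylphenyl to 4-methoxyphenyl.

The closest evidence is a step that the two limits leave unreadable from compound 2 to compound 3, where the acetyl appears. Also relevant are a step that the two limits leave unreadable from compound 1 to compound 2 and a step that the two limits leave unreadable from compound 1 to compound 3. None of these three gives a size or a direction, so they offer no basis for predicting a real change in this assay.

The expected change, which is no step beyond the scatter, is estimated as a number no higher from compound 3 to compound 4 (the limit leaves the size open).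

For compound 4 the expected value is 20000 nM, with an estimated range of 5000 nM to 40000 nM.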

Compound 4, half-maximal inhibitory concentration: 18000 nM
For compound 4 the middle estimate is 1.1-fold (0.05 log units) above the measured one; low and high end bracket the measured number.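

In this assay, among these compounds, compound 4 gives 18000 nM, the only reading in this set that is a number and not a limit. Compound 1, compound 2 and compound 3 each stand at a limit, so the steps among them cannot be read: the limit of > 20000 nM in this assay, at which 3 of the 4 values shown sit. The new steps are an at least 1.1-fold lower number from compound 3 to compound 4 (0.04 log units; that floor lies within the scatter), an at least 1.1-fold lower number from compound 2 to compound 4 (0.04 log units; that floor lies within the scatter) and an at least 1.1-fold lower number from compound 1 to compound 4 (0.04 log units; that floor lies within the scatter), so methoxy at this position brings the first measurable value, while a real gain in potency is neither shown nor ruled out.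

As far as these compounds go, how far compound 3 truly lies from compound 4 stays unknown, since only a floor can be given for that step. Also open, from the compounds shown here alone, is how an amine, a carboxylic acid or a longer chain such as ethoxy would read on the same aromatic carbon.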